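The source may hold more compounds than are shown below. What is called first, only, known or untested is meant among the compounds shown, and "the series" means these compounds.

Compound 1 has the structure `COC(=O)[C@@]1(C)CCC=C2[C@@H]1CC[C@@H](C)[C@]2(C)Cc1c[nH]c2c(Br)cccc12`, and compound 2, with the structure `COC(=O)[C@@]1(C)CCC=C2[C@@H]1CC[C@@H](C)[C@]2(C)Cc1c[nH]c2c(Cl)cccc12`, differs from it in one place: chloro in place of bromo on an aromatic carbon. In a functional assay on SW1573 cells (Homo sapiens) for inhibition, read by sulforhodamine B assay, with a stated time of 48 h (on this read-out higher numbers stand for weaker inhibition of growth and lower numbers for stronger inhibition of growth), compound 1 gives 14000 nM, and compound 2 gives 14000 nM, so the step of no change at the digits printed from compound 1 to compound 2 (within the scatter).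

Compound 3, with the structure `COC(=O)[C@@]1(C)CC[C@@H]2C3=C1CC[C@@H](C)[C@]3(C)C[C@@H]1c3cc(Br)ccc3N[C@H]21`, is built from the same atoms as compound 1 but joined differently; how the two cores differ is not broken down here. In this assay compound 3 gives 45000 nM, the highest of the three numbers and beyond the scatter from both compound 1 and compound 2.

Compound 4, with the structure `COC(=O)[C@@]1(C)CC[C@@H]2C3=C1CC[C@@H](C)[C@]3(C)C[C@@H]1c3cc(Cl)ccc3N[C@H]21`, has not been measured. It differs from compound 3 in one place: chloro in place of bromo on an aromatic carbon. Within the data shown here, this is the same kind of change as the one from compound 1 to compound 2, though the surroundings are not the same: in compound 2 the chloro sits on a ring that is part of a fused system of two rings, ortho to a fused ring and meta to a fused ring, while in compound 4 it sits on a ring that is part of a fused system of five rings, meta to a fused ring and para to a fused ring. Because the step of no change at the digits printed from compound 1 to compound 2 (within the scatter), the expected step of no change at the digits printed from compound 3 to compound 4 (within the scatter) is estimated to be similarly flat. On that basis compound 4 is expected to give about 45000 nM, with a likely range from 20000 nM to 100000 nM.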

Compound 4, concentration for 50% growth inhibition: 38000 nM
Compound 4: middle estimate off by 1.2-fold (0.07 log units), on the high side, and the stated range covers the measured number.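

In this assay, chloro in place of bromo on the second core gives a 1.2-fold lower number from compound 3 to compound 4 (0.07 log units; within the scatter). Set beside the same exchange on the core of compound 1, the two steps agree: the same change on two cores in this assay, no change at the digits printed (within the scatter) from compound 1 to compound 2 and a 1.2-fold lower number (0.07 log units; within the scatter) from compound 3 to compound 4, 1.2-fold (0.07 log units) apart, within the scatter of two such steps

So, for these two cores, this exchange of one halogen for another carries over in the simple sense that neither step can be told apart from the scatter, but that is a weak test, since two flat steps would agree whether or not the cores respond alike to a change with a real effect, and the halogen also sits at a different place on each core.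

The compounds shown leave open whether a different group at these places, such as an amine, a methoxy group or a nitrile, or plain hydrogen with no halogen at all, would shift the number on either core, and whether any such shift would be the same on both. They also leave open what would follow if the methyl ester found on all four compounds gave way to a carboxylic acid or an amide.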